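Methoxy in Place of Fluoro on the Aryl Amino Group

The source may report more compounds than this note shows. Statements on the series, on what has been measured and on what is new or still open speak of the compounds shown alone.

Three close analogues share a core and have been tested in a functional assay on MKN-74 cells (Homo sapiens) for antiproliferative activity, with a stated time of 24 h; a lower number here means a stronger inhibitor, a higher number a weaker inhibitor. Compound 1 `NC(=O)c1c(NC(=O)c2ccccc2Cl)sc2c1CCN(Cc1ccccc1)C2` gives 14500 nM. Compound 2 `NC(=O)c1c(NC(=O)c2ccccc2Cl)sc2c1CCN(Cc1ccccc1F)C2` gives 12900 nM, and compound 3 `NC(=O)c1c(NC(=O)c2ccccc2Cl)sc2c1CCN(C(=S)Nc1ccccc1F)C2` gives 12600 nM. The steps among them are all small: a 1.1-fold lower number from compound 1 to compound 2 (0.05 log units; within the scatter), a 1.2-fold lower number from compound 1 to compound 3 (0.06 log units; within the scatter), and a 1.0-fold lower number from compound 2 to compound 3 (0.01 log units; within the scatter). Compound 3 therefore shows the lowest of the three numbers, but its distance to compound 2 and to compound 1 is within the scatter, so no order among the three can be read from these values.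

Compound 4 `COc1ccccc1NC(=S)N1CCc2c(sc(NC(=O)c3ccccc3Cl)c2C(N)=O)C1` differs from compound 3 in one place: methoxy in place of fluoro on an aromatic carbon. Among the measured compounds shown here, the only measured step touching this part of the molecule is the one in which fluoro replaced hydrogen, a 1.1-fold lower number from compound 1 to compound 2 (0.05 log units; within the scatter), and it stayed within the scatter; the exchange of the whole group on the ring nitrogen, a 1.0-fold lower number from compound 2 to compound 3 (0.01 log units; within the scatter), likewise changed nothing beyond the scatter. A step of no more than the scatter is therefore expected in this assay, with no preferred direction, so that the estimated step is a 1.1-fold lower number from compound 3 to compound 4 (0.02 log units; within the scatter). Compound 4 is expected to give about 12000 nM, within a range from 5000 nM to 30000 nM.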

Compound 4, half-maximal inhibitory concentration: 35200 nM
Beside the measured number, compound 4's estimate is 2.9-fold (0.47 log units) below it; measured number outside the range, above it.
By their numbers in this assay, from the lowest: compounds 3, 2 and 1 (each within the scatter of the next); then compound 4.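

In this assay, among the compounds shown here, this position is the first to respond: going from 2-fluorophenyl to 2-methoxyphenyl gives a 2.8-fold higher number from compound 3 to compound 4 (0.45 log units; beyond the scatter), a modest step, but one that leaves the scatter where every earlier step stayed within it. Against the groups on the ring nitrogen of the other two compounds the picture is the same, with a 2.7-fold higher number from compound 2 to compound 4 (0.44 log units; beyond the scatter) and a 2.4-fold higher number from compound 1 to compound 4 (0.39 log units; beyond the scatter), so compound 4 stands apart from three compounds that could not be ordered. Nothing available explains this step, and the data give its size only.

The compounds shown leave open whether the higher number belongs to methoxy alone or would also come with ethoxy, hydroxyl or an amine at this place. They also leave open whether methoxy on the benzyl group of compound 1 would bring a similar step.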